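A few compounds are considered here, and "the series" means these few. Any claim that something is new, unique, unknown or untested is made for them only; others in the source may bear on it.

Measured compounds:
- Compound 1, `O=C1c2sc(C#Cc3ccccc3)nc2CN1C1CC1`, gives 23 nM in an assay on HEK293 cells for negative allosteric modulation of metabotropic glutamate receptor 5 (Homo sapiens), read by FLIPR, with a stated time of 1 h; a lower number here means a stronger inhibitor, a higher number a weaker inhibitor.
- Compound 2, `CC(C)CN1CCc2nc(C#Cc3ccccc3)sc2C1`, gives 650 nM in this assay.

Of these two numbers, compound 2 holds the higher one; the number of compound 1 lies below it by a gap that is beyond the usual scatter. Compound 3, `O=C(C1CC12CCC2)N1CCc2nc(C#Cc3ccccc3)sc2C1`, is not yet measured. It differs from compound 2 in one place: a group of 8 heavy atoms (7 carbon, 1 oxygen; one three-membered non-aromatic ring of carbon only, one four-membered non-aromatic ring of carbon only) in place of a group of 4 heavy atoms (4 carbon; no ring), on an amine nitrogen in a ring. For the measured compounds named here, compound 1, the only compound with the lower number here, also carries a carbonyl on its core, so the carbonyl entering at the amine nitrogen in compound 3 is taken as pointing downward; the expected change is a substantial drop, beyond the scatter, because compound 1 gives 23 nM. Going by the values given here, with only two measured compounds, the size of this expected step rests on a thin base. Compound 3 is expected to give about 80 nM, within a range from 20 nM to 400 nM. The expected step of an 8.1-fold lower number from compound 2 to compound 3 (0.91 log units; beyond the scatter) is thus downward, beyond the scatter.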

Compound 3, half-maximal inhibitory concentration: > 10000 nM
Compound 3 was reported as a limit (the forecaster's own chance of this, stated with the estimate: 3%); middle value at least 120-fold (2.09 log units) away from the limit.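

Compound 3 is reported in this assay only as a limit, > 10000 nM, and not as a number. At this amine nitrogen in a ring, exchanging the isobutyl for the group with the carbonyl and the two small carbon rings gives an at least 15-fold higher number from compound 2 to compound 3 (1.18 log units; beyond the scatter), so this position is shown for the first time to be sensitive to the group it carries, and a carbonyl there does not by itself bring a low number. The size of that step is read from a limit: the limit of > 10000 nM in this assay, at which 1 of the 3 values shown sits.

The compounds shown do not separate the carbonyl from the two rings as the source of the loss. An acetyl group, with the carbonyl and no ring, or a cyclopropylmethyl group, with a ring and no carbonyl, on this nitrogen would leave that question open no longer.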